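This account rests on a few compounds, and the source may have more. Where it says the series, first, only, none or still open, it means among the compounds named here.

Compound 1, `O=C(Nc1cc(-c2ccccc2)nn1-c1ccccc1)c1ccccc1`, in a functional assay on cells for positive allosteric modulation of metabotropic glutamate receptor 5 (Rattus norvegicus), read by calcium flux (a higher number here means that more compound is needed for the effect, a lower number that less compound is needed), gives 203 nM. Compound 2, `O=C(Nc1cc(-c2ccccc2)nn1-c1ccccc1)c1cccc([N+](=O)[O-])c1`, gives 39 nM. Compound 3, `O=C(Nc1cc(-c2ccccc2)nn1-c1ccccc1F)c1ccccc1`, gives 104 nM.

Compound 3 sits second highest of the three numbers. Its nearest neighbour is compound 1: the step of a 2.0-fold lower number from compound 1 to compound 3 (0.29 log units; within the scatter) lies within the scatter, so the two cannot be told apart on these numbers. Compound 2 stands furthest off, with the lowest number of the set.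

Compound 4, `O=C(Nc1cc(-c2ccccc2)nn1-c1ccccc1Cl)c1ccccc1`, differs from compound 3 in one place: chloro in place of fluoro on an aromatic carbon. Among the measured compounds shown here, no measured pair shows one halogen replaced by another at this position, so nothing directly bears on the size of this step. For the measured compounds named here, the only change at the same place is the step of a 2.0-fold lower number from compound 1 to compound 3 (0.29 log units; within the scatter), which stayed within the scatter. The step of a 5.2-fold lower number from compound 1 to compound 2 (0.72 log units; beyond the scatter) was the one modest move in the set, but it sits on the other aromatic ring and tells nothing about the present change.

On that basis the expected step of a 1.2-fold lower number from compound 3 to compound 4 (0.06 log units; within the scatter) is one of no change beyond the scatter. Compound 4 is therefore estimated at 90 nM, with a range from 35 nM to 230 nM.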

Compound 4, half-maximal effective concentration: 62 nM
Beside the measured number, compound 4's estimate is 1.5-fold (0.16 log units) above it; the range from low to high includes it.
By their numbers in this assay, from the lowest: compounds 2, 4, 3 and 1 (each within the scatter of the next, the first and the last beyond it).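

In this assay, among the compounds shown here, the step of a 3.3-fold lower number from compound 1 to compound 4 (0.52 log units; beyond the scatter) is the first at this place, on an aromatic carbon ortho to a large group, to lie beyond the scatter, so a change here can shift the number and such a shift is no longer confined to the other aromatic ring, which carries the nitro group. The step of a 1.7-fold lower number from compound 3 to compound 4 (0.22 log units; within the scatter) nevertheless stays within the scatter, so 2-fluorophenyl and 2-chlorophenyl cannot be told apart on these numbers, and the compounds give no ground for ranking one of these halogens above the other. Nothing given here accounts for either step.

The compounds shown leave open how this place responds to groups other than halogens, such as a methyl, a methoxy or an amine, and whether a larger halogen such as bromo would continue the picture or depart from it. They also leave open whether the chloro of compound 4 and the nitro of compound 2, placed together on one molecule, would add up or whether one step would change the size of the other.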